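Extending the acetamido group of compound 3 by carboxymethyl

The source may hold more compounds than are shown below. What is called first, only, known or untested is meant among the compounds shown, and "the series" means these compounds.

Measured so far in an in vitro assay on Sf9 cells for binding affinity to 17-beta-hydroxysteroid dehydrogenase type 1 (Homo sapiens), read by scintillation counting, with a stated time of 10 min, tested at 100 nM; on this read-out lower numbers stand for a weaker effect and higher numbers for a stronger effect at the one concentration tested:
compound 1 `Oc1cccc(-c2ccc3c(-c4cccnc4)c(O)ccc3c2)c1`, 87%
compound 2 `O=C(O)c1cccc(-c2c(O)ccc3cc(-c4cccc(O)c4)ccc23)c1`, 45%
compound 3 `CC(=O)Nc1cccc(-c2c(O)ccc3cc(-c4cccc(O)c4)ccc23)c1`, 35%

Compound 3 gives the lowest of the three numbers. The step of a number 10 percentage points lower from compound 2 to compound 3 (within the scatter) lies within the scatter, so no order between compound 2 and compound 3 can be read from it. The only large movement in the set is a number 42 percentage points lower from compound 1 to compound 2 (beyond the scatter), where a carboxy-bearing phenyl arrived on an aromatic carbon.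

Compound 4 `O=C(O)CCC(=O)Nc1cccc(-c2c(O)ccc3cc(-c4cccc(O)c4)ccc23)c1` differs from compound 3 by carboxymethyl in place of hydrogen on a saturated chain carbon bound to a carbonyl carbon. Among the compounds with values here, two measured steps bear on this change. In a number 42 percentage points lower from compound 1 to compound 2 (beyond the scatter) a carboxy group came in and the number fell far beyond the scatter; in a number 10 percentage points lower from compound 2 to compound 3 (within the scatter) carboxy gave way to acetamido with no movement beyond the scatter. Compound 4 keeps the acetamido link and brings a carboxy back, now on a saturated chain carbon bound to a carbonyl carbon. Within the data shown here, no measured step adds a group at such a chain position, so the expected step of a number 5 percentage points lower from compound 3 to compound 4 (within the scatter) is a small lowering, not clearly beyond the scatter. Compound 4 is estimated at 30%, with a range from 10% to 52%.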

Compound 4, a percentage reported as inhibition, at one concentration (the size of the read-out at that concentration, not a potency): < 10%
Compound 4 was reported as a limit; the forecaster's own chance of this, stated with the estimate: 0%; at least 20 percentage points between middle value and limit.
By their numbers in this assay, from the lowest: compounds 3 and 2 (each within the scatter of the next); then compound 1. At a limit, below all of these: compound 4.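

In this assay compound 4 is recorded as a limit of the assay, not as a number: the limit of < 10% in this assay, at which 1 of the 4 values shown sits.

Carboxymethyl in place of hydrogen on a saturated chain carbon bound to a carbonyl carbon gives a number at least 25 percentage points lower from compound 3 to compound 4 (beyond the scatter), so this position, unlike the exchange of carboxy for acetamido on an aromatic carbon, does respond beyond the scatter. Set against the carboxy on an aromatic carbon, ((2-carboxyethyl)carbonyl)amino gives a number at least 35 percentage points lower from compound 2 to compound 4 (beyond the scatter), so a carboxy carried on this chain does not retain the number seen with the carboxy on the aromatic carbon.

The compounds shown do not separate the contribution of the carboxylic acid from that of the longer chain. A methyl ester or an amine on the same chain would tell these apart, as would a plain propyl group in place of 2-carboxyethyl.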